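This account rests on a few compounds, and the source may have more. Where it says the series, first, only, none or still open, it means among the compounds named here.

Notes on the series. Compound 1 `CCC1=C(O)c2c(oc(-c3ccccc3C(F)(F)F)cc2=O)C(CC)(CC)C1=O` carries a trifluoromethyl on the pendant ring; in a functional assay on KB cells (Homo sapiens) for antiproliferative activity, read by sulforhodamine B assay, with a stated time of 3 days (a lower number here means that less compound is needed, a higher number that more compound is needed for the effect), compound 1 gives 45.6 uM. Compound 2 `CCC1=C(O)c2c(oc(-c3ccccc3F)cc2=O)C(CC)(CC)C1=O` has fluoro in place of that trifluoromethyl. For compound 2 this assay reports only a limit, > 56.2 uM, and no number stands for it (the limit of > 56.2 uM in this assay, at which 1 of the 2 values shown sits). Within the data shown here, the single measured step, an at least 1.2-fold higher number from compound 1 to compound 2 (0.09 log units; that floor lies within the scatter), is therefore a floor rather than a size, and it tells little about where compound 2 actually lies.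

Compound 3 `CCC1=C(O)c2c(oc(-c3cc(C)ccc3F)cc2=O)C(CC)(CC)C1=O` differs from compound 2 in one place: methyl in place of hydrogen on an aromatic carbon. No measured step in the series introduces a methyl or touches this part of the ring, so nothing shown bears directly on the change; the one step at hand concerns a different substituent. In this assay the step that the limit leaves unreadable from compound 2 to compound 3 is expected to stay within the scatter. Compound 2 already sits at the limit of this assay. Compound 3 is estimated at 60 uM, with a range of 25 uM to 150 uM, and a limit rather than a number is about as likely as not.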

Compound 3, concentration for half-maximal effect: 47.3 uM
For compound 3 the middle estimate is 1.3-fold (0.10 log units) above the measured one; the range from low to high includes it.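

Methyl in place of hydrogen, on the aromatic carbon meta to a large group and para to a fluoro group, yields a readable number: in this assay compound 3 gives 47.3 uM. Among these compounds, the change reads as an at least 1.1-fold lower number from compound 2 to compound 3 (0.07 log units; that floor lies within the scatter), so this position of the 2-fluorophenyl ring accepts a methyl without the number passing out of the measurable range, and the series now holds a first reading for this place on the ring. The true size of the methyl step stays unread because only a bound is available on the side of compound 2: the limit of > 56.2 uM in this assay, at which 1 of the 3 values shown sits.

On these data alone, what an amine, a carboxylic acid or a longer chain at this same carbon would do to the number in this assay remains open, as does whether the outcome with methyl carries over to other groups at this place. Also open, as far as these compounds go, are the actual position of compound 2 and whether the same methyl would give a comparable result on the trifluoromethyl ring of compound 1.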